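Swapping one chloro for fluoro on the benzyl group

The source may report more compounds than this note shows. Statements on the series, on what has been measured and on what is new or still open speak of the compounds shown alone.

Compound 1 `COc1ccc(C(=O)CSc2nc(Cc3c(Cl)cccc3Cl)cc(=O)[nH]2)cc1` is the reference point in an ADME assay on MT4 cells (Homo sapiens) for cytotoxicity, read by MTT assay; on this read-out higher numbers stand for lower toxicity in this test and lower numbers for higher toxicity in this test. In this assay compound 1 gives > 11000 nM, which is a limit and not a number. Compound 2 `CCc1c(Cc2c(Cl)cccc2Cl)nc(SCC(=O)c2ccc(OC)cc2)[nH]c1=O` carries ethyl in place of hydrogen on an aromatic carbon of the shared core. Compound 2 gives > 54000 nM, which is also a limit. Going by the values given here, compound 1 therefore has no exact place on the scale, and the only measured step is a step that the two limits leave unreadable from compound 1 to compound 2.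

Compound 3 `COc1ccc(C(=O)CSc2nc(Cc3c(F)cccc3Cl)cc(=O)[nH]2)cc1` differs from compound 1 in one place: fluoro in place of chloro on an aromatic carbon. The 2,6-dichlorobenzyl group thus becomes 2-chloro-6-fluorobenzyl. The measured step gives no size to carry over, and it concerns a different change. Among the compounds with values here, no measured pair shows fluoro in place of chloro. With nothing pointing either way, no step beyond the usual scatter is expected in this assay, and the expected step is a step that the limit leaves unreadable from compound 1 to compound 3. For compound 3 the estimated value is 20000 nM, with an expected range of 7000 nM to 60000 nM.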

Compound 3, half-maximal cytotoxic concentration: > 12000 nM
Compound 3 gave a limit, no number; the forecaster's own chance of this, stated with the estimate: 60%; the middle value is on the limit's open side.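

Going by these compounds alone, compound 1 and compound 3 both give limits and not numbers in this assay, and no step between them can be read. The compounds shown leave open where compound 1, compound 2 and compound 3 would each fall on an exact scale, and whether fluoro in place of chloro shifts the read-out at all.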